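Compound 1 to compound 3: adding a second chloro

A few compounds are considered here, and "the series" means these few. Any claim that something is new, unique, unknown or untested is made for them only; others in the source may bear on it.

Results so far in a functional assay on HeLa cells (Homo sapiens) for antiproliferative activity, read by MTT assay, with a stated time of 72 h; a higher number here means a weaker inhibitor, a lower number a stronger inhibitor
compound 1 `COc1cc(-n2ncnc2-c2ccc(Cl)cc2)cc(OC)c1OC` > 10000 nM
compound 2 `COc1cc(-n2ncnc2-c2ccc(OC(F)(F)F)cc2)cc(OC)c1OC` > 10000 nM

Compound 1 reads > 10000 nM as a limit and not a number. Compound 2 reads > 10000 nM as a limit too. Compound 1 therefore offers no number to step from, and the limit of > 10000 nM in this assay, at which 2 of the 2 values shown sit, is the whole of the evidence. Going by the values given here, the only measured step is a step that the two limits leave unreadable from compound 1 to compound 2 and it gives no size or direction to carry over.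

Compound 3 `COc1cc(-n2ncnc2-c2ccc(Cl)c(Cl)c2)cc(OC)c1OC` has not yet been measured. It differs from compound 1 by chloro in place of hydrogen on an aromatic carbon, ortho to a chloro group and meta to a large group (chloro in place of hydrogen on an aromatic carbon), so 4-chlorophenyl becomes 3,4-dichlorophenyl.

The expectation starts from the limit of compound 1 at > 10000 nM, so no step beyond the scatter is expected in this assay and no direction can be argued. The expected step is a step that the limit leaves unreadable from compound 1 to compound 3 and it remains a rough estimate. For compound 3 the expected value is 12000 nM with an estimated range of 4000 nM to 30000 nM, and a report as a limit is expected to be the likeliest outcome.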

Compound 3, half-maximal inhibitory concentration: > 10000 nM
Compound 3: no number, only a limit (the forecaster's own chance of this, stated with the estimate: 75%); the middle value does not contradict the limit.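

In this assay compound 3 gives > 10000 nM, a limit and not a number. No step can be read from compound 1 to compound 3, because both rest on a limit: the limit of > 10000 nM in this assay, at which 3 of the 3 values shown sit. The compounds shown leave open whether any change to this group on the shared core would give a measurable value in this assay.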